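Replacing the Methylpiperazine with a Trifluoroacetamide

The source may report more compounds than this note shows. Statements on the series, on what has been measured and on what is new or still open speak of the compounds shown alone.

Three compounds sharing one core have been measured in an ADME assay on L02 cells (Homo sapiens) for cytotoxicity, read by MTT assay, with a stated time of 48 h; a lower number here means a stronger inhibitor, a higher number a weaker inhibitor:

compound 1 `CN1CCN(C[C@H]2CN(c3ccc(-n4cc(-c5ccccn5)cn4)c(F)c3)C(=O)O2)CC1`, where compound 1 gives 70 ug/mL
compound 2 `CN(C)S(=O)(=O)NC[C@H]1CN(c2ccc(-n3cc(-c4ccccn4)cn3)c(F)c2)C(=O)O1`, where compound 2 gives 158 ug/mL
compound 3 `CCNC(=O)NC[C@H]1CN(c2ccc(-n3cc(-c4ccccn4)cn3)c(F)c2)C(=O)O1`, where compound 3 gives only > 400 ug/mL, which is a limit of the assay rather than a number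

Among the numbers shown, compound 1 has the lowest; the nearest is compound 2, with a 2.3-fold higher number from compound 1 to compound 2 (0.35 log units; beyond the scatter). The remaining value is a limit, as stated in the limit of > 400 ug/mL in this assay, at which 1 of the 3 values shown sits.

Compound 4 `O=C1O[C@@H](CNC(=O)C(F)(F)F)CN1c1ccc(-n2cc(-c3ccccn3)cn2)c(F)c1` has not yet been measured. It differs from compound 1 in one place: ((trifluoromethyl)carbonyl)amino in place of 4-methylpiperazin-1-yl on a saturated chain carbon bound to a saturated ring carbon. Two measured steps start from the same group at the same place. Exchanging it for one chain group gave a 2.3-fold higher number from compound 1 to compound 2 (0.35 log units; beyond the scatter); exchanging it for another gave an at least 5.7-fold higher number from compound 1 to compound 3 (0.75 log units; beyond the scatter). Both moved the number upward beyond the scatter, so compound 4 is expected to follow the same direction, with a step of roughly a 2.9-fold higher number from compound 1 to compound 4 (0.46 log units; beyond the scatter). Compound 4 is therefore estimated at 200 ug/mL, between 80 ug/mL and 400 ug/mL.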

Compound 4, half-maximal inhibitory concentration: > 400 ug/mL
Compound 4 was reported as a limit; the forecaster's own chance of this, stated with the estimate: 35%; middle value at least 2.0-fold (0.30 log units) away from the limit.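

In this assay compound 4 gives a limit of the assay, not a number: the limit of > 400 ug/mL in this assay, at which 2 of the 4 values shown sit. Exchanging 4-methylpiperazin-1-yl for ((trifluoromethyl)carbonyl)amino gives an at least 5.7-fold higher number from compound 1 to compound 4 (0.75 log units; beyond the scatter), and exchanging the dimethylsulfamoyl on the amine nitrogen for (trifluoromethyl)carbonyl gives an at least 2.5-fold higher number from compound 2 to compound 4 (0.40 log units; beyond the scatter). At this place, on a saturated chain carbon bound to a saturated ring carbon, a second carbonyl-bearing amino group therefore reaches the limit, so the result with compound 3 no longer rests on the (ethylcarbamoyl)amino group alone.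

The step from compound 3 to compound 4 cannot be read, so these two groups cannot be ranked against each other. On these data alone, it also remains open where a plain primary amine or a morpholine ring at this place would fall, and whether either would give a readable number in this assay.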